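A few compounds are considered here, and "the series" means these few. Any claim that something is new, unique, unknown or untested is made for them only; others in the source may bear on it.

Measured so far in an ADME assay on microsomes (Homo sapiens) for metabolic stability; a higher number here means that the compound lasts longer, a lower number that the compound disappears faster:

- compound 1 `CC(C)(C)C(=O)N1N=CCC1c1cocn1`: > 1.5 h
- compound 2 `N#Cc1cc(N2CCC(C(=O)N3N=CC[C@H]3c3cc(F)cc(F)c3)CC2)ncn1`: 3.3 h
- compound 3 `CC(C)C(=O)N1N=CCC1c1ccccc1`: > 1.5 h

Compound 1 stands at a limit of this assay rather than at a number; its half-life is given as > 1.5 h, and a limit is all that the run reports for it. Compound 3 sits at the same limit, > 1.5 h, again a limit and not a measured number. Compound 2 is the only one of the three with a number, 3.3 h. The picture across the three is therefore flat: every measured compound lasts through the window of this assay, and nothing here separates one from another, as the evidence shows (the limit of > 1.5 h in this assay, at which 2 of the 3 values shown sit).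

Compound 4 `CC(C)(C)C(=O)N1N=CCC1C1CCCC1` is the next compound. It differs from compound 1 in one place (cyclopentyl in place of 1,3-oxazol-4-yl on a saturated ring carbon). Going by the values given here, no step between measured compounds covers a change of this kind, so there is nothing in the data that points to either direction. The working expectation is that the step from compound 1 to compound 4 in this assay, a number no higher from compound 1 to compound 4 (the limit leaves the size open), stays within the usual scatter, with compound 4 estimated at 1.5 h, in the range 0.6 h to 4 h.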

Compound 4, half-life: 0.0983 h
For compound 4 the middle estimate is 15-fold (1.18 log units) above the measured one, and the stated range ends above it.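

Cyclopentyl in place of 1,3-oxazol-4-yl on a saturated ring carbon gives an at least 15-fold lower number from compound 1 to compound 4 (1.18 log units; beyond the scatter) in this assay, the first single change in the series with a readable effect, and a large one. Going by these compounds alone, compound 1 stands at a limit, > 1.5 h, so its value fixes only one side of the step. Within the data shown here, the flat picture from the earlier compounds therefore does not hold at this position, where the group carried on the ring carbon can decide whether a compound stays within the window of the assay, and the full size of the step remains open because one end of it is a limit: the limit of > 1.5 h in this assay, at which 2 of the 4 values shown sit.

The group leaving and the group entering differ at once in the aromatic ring and in the hetero atoms, so this single pair cannot say which of the two goes with the drop. Also open, on these data alone, is where a tetrahydrofuranyl group, a saturated five-membered ring that keeps an oxygen, or an open pentyl chain would fall at this position on the shared core.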